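Adding a Thiazole Arm to Compound 3: Expected Cytotoxicity

This account rests on a few compounds, and the source may have more. Where it says the series, first, only, none or still open, it means among the compounds named here.

Of the compounds shown here, three that share one core have been tested in an ADME assay on cells (Homo sapiens) for cytotoxicity, read by polymerase chain reaction, with a stated time of 3 days; on this read-out higher numbers stand for lower toxicity in this test and lower numbers for higher toxicity in this test. Compound 1, `Nc1nc(Cl)c(-c2nc3ccccc3o2)c(N[C@@H]2C[C@H](CO)[C@@H](O)[C@H]2O)n1`, gives 12000 nM in this assay. Compound 2, `COc1ccc2nc(-c3c(Cl)nc(N)nc3N[C@@H]3C[C@H](CO)[C@@H](O)[C@H]3O)sc2c1`, returns only a limit of the test, > 25000 nM, which is not a number. Compound 3, `CNc1nc(C)c(-c2nc3ccccc3s2)c(N[C@@H]2C[C@H](CO)[C@@H](O)[C@H]2O)n1`, likewise returns only a limit, > 25000 nM. Among the measured compounds shown here, two of the three values sit at the limit of > 25000 nM in this assay, at which 2 of the 3 values shown sit, so compound 3 stands at the very top of what this test can report, without a number of its own, and no step between two measured compounds is available to weigh against it.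

Compound 4, `Cc1nc(NCc2nccs2)nc(N[C@@H]2C[C@H](CO)[C@@H](O)[C@H]2O)c1-c1nc2ccccc2s1`, has not yet been measured. It differs from compound 3 in one place: 1,3-thiazol-2-yl in place of hydrogen on a saturated chain carbon bound to a nitrogen on an aromatic ring. With compound 3 sitting at a limit, there is no measured number to anchor a change to, and the expectation is that a number no higher from compound 3 to compound 4 (the limit leaves the size open) will come out as no step beyond the scatter, with a fair chance that the test again reports only a limit. Compound 4 is therefore expected to give about 25000 nM in this assay, with a likely range from 8000 nM to 60000 nM.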

Compound 4, half-maximal cytotoxic concentration: 23000 nM
The estimate for compound 4 lay 1.1-fold (0.04 log units) above the measured number; measured number inside the range.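

With 1,3-thiazol-2-yl in place of hydrogen on a saturated chain carbon bound to a nitrogen on an aromatic ring, this assay returns a true number rather than a limit: compound 4 gives 23000 nM. The step reads an at least 1.0-fold lower number from compound 3 to compound 4 (0.03 log units; that floor lies within the scatter), so this place can carry a five-membered aromatic ring without the data showing a clear rise in toxicity in this test, although a floor alone cannot rule one out. Compound 3 gives > 25000 nM, which is a limit of the test and not a number, so the true size of the step stays unknown: the limit of > 25000 nM in this assay, at which 2 of the 4 values shown sit.

The compounds shown leave open whether the sulfur and nitrogen of 1,3-thiazol-2-yl matter here, or whether a phenyl ring on the same carbon would read the same in this assay. They also leave open how a longer chain or a carboxylic acid at this place would read.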